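Swapping a Propyl Chain for Bromine on the Outer Ring

This account rests on a few compounds, and the source may have more. Where it says the series, first, only, none or still open, it means among the compounds named here.

Of the compounds shown here, three built on the same core have been tested in a functional assay on HEK293 cells for activation of melanin-concentrating hormone receptor 1 (Homo sapiens), read by inositol phosphate accumulation; on this read-out higher numbers stand for an effect only at larger amounts of compound and lower numbers for an effect already at smaller amounts. Compound 1 `CCCc1cc(N)c2cc(NC(=O)c3ccc(-c4ccc(Cl)cc4)cc3)ccc2n1` gives 75 nM. Compound 2 `CCCc1cc(OC)c2cc(NC(=O)/C=C/c3ccc(C(F)(F)F)cc3)ccc2n1` gives 360 nM. Compound 3 `CCCc1ccc(/C=C/C(=O)Nc2ccc3nc(CCC)cc(N)c3c2)cc1` gives 3600 nM, the highest number of the three: compound 2 lies nearest to it, with a lower number by a gap beyond the usual scatter, and compound 1 lies furthest, with a lower number still.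

Compound 4 `CCCc1cc(N)c2cc(NC(=O)/C=C/c3ccc(Br)cc3)ccc2n1` has not yet been measured. It differs from compound 3 in one place: bromo in place of propyl on an aromatic carbon. The measured set offers only indirect guidance here. Compound 1, which also carries a halogen on its outer ring, gives the lowest number of the three, but it also has a different linker between the two rings, so its value cannot be read as a clean comparison with compound 3. Still, a halogen in place of a chain at this spot is the kind of change that usually moves the number downward. Compound 4 is therefore expected to show a step of a 9.0-fold lower number from compound 3 to compound 4 (0.95 log units; beyond the scatter) toward a lower number, beyond the scatter. Compound 4 is estimated at 400 nM, with a range from 100 nM to 1500 nM.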

Compound 4, half-maximal effective concentration: 93 nM
Estimate against measurement, compound 4: 4.3-fold (0.63 log units) above; measured number below the stated range.
By their numbers in this assay, from the lowest: compounds 1 and 4 (each within the scatter of the next); then compound 2; then compound 3.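

Among these compounds, for the first time in this set, two compounds differ in one place only, so this position on the outer ring can be read directly: in this assay, putting bromo in place of propyl on an aromatic carbon, para to a large group, gives a 39-fold lower number from compound 3 to compound 4 (1.59 log units; beyond the scatter) and counts as a large step. The number therefore depends strongly on what sits at this one spot, even with everything else in the molecule held the same. The swap replaces a chain of 3 heavy atoms with a single bromine atom, neither group has any hydrogen-bond donors or acceptors, and no measurement here explains why the number moves so far.

Still open, on these data alone, is whether the step comes from the arrival of bromine or from the loss of the propyl chain, a question that a plain hydrogen, a methyl group, a chlorine atom or a methoxy group at this spot could help to settle. As far as these compounds go, it is also open whether the same swap would give a step of similar size on a compound with the linker of compound 1, or with a methoxy group in place of the amine on the shared core.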